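Azetidin-1-yl Exchanged for 4-Methylpiperazin-1-yl on a Shared Core

The source may report more compounds than this note shows. Statements on the series, on what has been measured and on what is new or still open speak of the compounds shown alone.

Of the compounds shown here, two have been tested in a functional assay on SV5A8 cells (Homo sapiens) for cytotoxicity; a higher number here means a weaker inhibitor, a lower number a stronger inhibitor. Compound 1 `Cc1ccc2c(NCc3ccc(NC(=O)C4CCN(Cc5ccccc5)CC4)cc3)nc(N3CCC3)nc2c1` carries an azetidin-1-yl group on the shared core. In this assay compound 1 gives no number but only a limit, > 8500 nM (the limit of > 8500 nM in this assay, at which 1 of the 2 values shown sits). Compound 2 `Cc1ccc2c(NCc3ccc(NC(=O)C4CCN(Cc5ccccc5F)CC4)cc3)nc(N(C)C)nc2c1` is the second compound measured. In this assay compound 2 also gives only a limit, > 6670 nM (the limit of > 6670 nM in this assay, at which 1 of the 2 values shown sits). Going by the values given here, compound 1 therefore stands at a limit, and the one further value shown is a limit as well, so the two values cannot be ordered against each other.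

Compound 3 `Cc1ccc2c(NCc3ccc(NC(=O)C4CCN(Cc5ccccc5)CC4)cc3)nc(N3CCN(C)CC3)nc2c1` differs from compound 1 in one place: 4-methylpiperazin-1-yl in place of azetidin-1-yl on an aromatic carbon. Among the compounds with values here, no measured step between two compounds exists in this set, so the size of this change cannot be read from measured data. The step is expected to be a step that the limit leaves unreadable from compound 1 to compound 3, that is, none beyond the scatter, because compound 1 gives only > 8500 nM. Compound 3 is estimated at 10000 nM, within 3000 nM to 30000 nM, and a limit rather than a number is the likelier outcome for compound 3.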

Compound 3, half-maximal inhibitory concentration: > 17700 nM
Compound 3: only a limit was reported; the forecaster's own chance of this, stated with the estimate: 70%; at least 1.7-fold (0.24 log units) between middle value and limit.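

Compound 3 also gives only a limit, > 17700 nM in this assay, and not a number. With limits on both sides, the step from compound 1 to compound 3 cannot be read, so the exchange of azetidin-1-yl for 4-methylpiperazin-1-yl has no readable size. The compounds shown leave open what half-maximal inhibitory concentration any of them has in this assay as a number.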